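From 1,3-diaminopropyl to 1,4-diaminobutyl: what to expect

A few compounds are considered here, and "the series" means these few. Any claim that something is new, unique, unknown or untested is made for them only; others in the source may bear on it.

compound 1 `CCCCCCCCCCCCNC(=O)CNC(=O)CN` gives 5010 nM
compound 2 `CCCCCCCCCCCCNC(=O)[C@@H](N)CCC(N)=O` gives 7940 nM
compound 3 `CCCCCCCCCCCCNC(=O)C(N)CCN` gives 1260 nM

In a functional assay on HL-60 cells (Homo sapiens) for activation (on this read-out higher numbers stand for an effect only at larger amounts of compound and lower numbers for an effect already at smaller amounts), compound 3 stands lowest of the three at 1260 nM and so acts at the smallest amounts. One measured step stays small (a 1.6-fold higher number from compound 1 to compound 2 (0.20 log units; within the scatter)) and sets no order. The other two are modest (a 4.0-fold lower number from compound 1 to compound 3 (0.60 log units; beyond the scatter) and a 6.3-fold lower number from compound 2 to compound 3 (0.80 log units; beyond the scatter)) and both end at compound 3.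

Compound 4 `CCCCCCCCCCCCNC(=O)C(N)CCCN` carries aminomethyl in place of amino on a saturated chain carbon, three bonds along the chain from an amine nitrogen and a carbonyl carbon. Cut one bond further out, this reads 1,3-diaminopropyl to 1,4-diaminobutyl.

Going by the values given here, no measured step makes this exact change, so the evidence is indirect. Each measured step swaps a whole group, and the largest of them (a 6.3-fold lower number from compound 2 to compound 3 (0.80 log units; beyond the scatter)) is still only modest. The change here is smaller, so a modest step is the most that seems likely, in either direction. In this assay the step expected for compound 4 is a 1.0-fold higher number from compound 3 to compound 4 (0.01 log units; within the scatter) and so none beyond the scatter. The estimate for compound 4 is 1300 nM with an expected range from 500 nM to 3500 nM for the measurement.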

Compound 4, half-maximal effective concentration: 2510 nM
Beside the measured number, compound 4's estimate is 1.9-fold (0.29 log units) below it, and the stated range covers the measured number.
By their numbers in this assay, from the lowest: compounds 3, 4, 1 and 2 (each within the scatter of the next, the first and the last beyond it).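

In this assay, going by these compounds alone, the change from 1,3-diaminopropyl to 1,4-diaminobutyl gives the first direct look at lengthening this chain by itself, and the result, a 2.0-fold higher number from compound 3 to compound 4 (0.30 log units; within the scatter), does not allow the two chains to be put in order. Set against the 1-amino-3-carbamoylpropyl group, the 1,4-diaminobutyl group still shows a difference beyond the scatter, a 3.2-fold lower number from compound 2 to compound 4 (0.50 log units; beyond the scatter), so swapping that group for a diamine chain has now gone the same way with both chain lengths; set against the (((aminomethyl)carbonyl)amino)methyl group, it shows none beyond the scatter, a 2.0-fold lower number from compound 1 to compound 4 (0.30 log units; within the scatter), although the shorter diamine chain of compound 3 did. Nothing measured here offers an explanation for these numbers.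

Going by these compounds, it remains open whether a still longer chain, such as 1,5-diaminopentyl, would stay close to these two diamine chains or move away from them. On these data alone, it is equally open what would happen if the amine at the end of the chain gave way to a carboxylic acid or a hydroxyl group, which would show how much depends on that end amine.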